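Swapping chloro for hydroxy on a thiosemicarbazone aryl ring

The source may report more compounds than this note shows. Statements on the series, on what has been measured and on what is new or still open speak of the compounds shown alone.

Measured compounds:
- compound 1, `Oc1ccc(/C=N/NC(=S)Nc2ccc(Cl)cc2)cc1`: 287000 nM
- compound 2, `Cc1ccccc1NC(=S)N/N=C/c1ccc(O)cc1`: 36500 nM
- compound 3, `O=[N+]([O-])c1ccccc1NC(=S)N/N=C/c1ccc(O)cc1`: 39300 nM

All three share a core built from a hydroxyphenyl group linked through a thiourea to a second aromatic ring, and they were tested in an assay for inhibition of ribonucleoside-diphosphate reductase RR1 (Homo sapiens), with a stated time of 30 min; on this read-out higher numbers stand for weaker inhibition and lower numbers for stronger inhibition. Compound 1 gives the highest number of the three, and its gap to compound 3 and to compound 2 lies beyond the scatter, so compound 1 is the weakest inhibitor of this set. Among the compounds with values here, the only measured single change is a 1.1-fold higher number from compound 2 to compound 3 (0.03 log units; within the scatter), which shows that exchanging one group for another on that second ring left the number essentially unchanged.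

Compound 4, `Oc1ccc(/C=N/NC(=S)Nc2ccc(O)cc2)cc1`, differs from compound 1 by hydroxy in place of chloro on an aromatic carbon. Within the data shown here, no measured step tests this exchange directly; the one step available, from compound 2 to compound 3, concerns different groups and was within the scatter. The expectation therefore is a change of a 1.9-fold lower number from compound 1 to compound 4 (0.28 log units; within the scatter), small and uncertain in direction. For compound 4 in this assay the estimated value is 150000 nM, with a range from 40000 nM to 500000 nM.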

Compound 4, half-maximal inhibitory concentration: 43300 nM
For compound 4 the middle estimate is 3.5-fold (0.54 log units) above the measured one; measured number inside the range.
By their numbers in this assay, from the lowest: compounds 2, 3 and 4 (each within the scatter of the next); then compound 1.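

In this assay the exchange of chloro for hydroxy gives a 6.6-fold lower number from compound 1 to compound 4 (0.82 log units; beyond the scatter), which shows that the number responds to the group at this place on the aromatic ring, para to a large group. Within the data shown here, the only earlier step, a 1.1-fold higher number from compound 2 to compound 3 (0.03 log units; within the scatter), involved other groups and stayed within the scatter, so it gave no sign of such a response. No supporting data are available on what lies behind the difference between chloro and hydroxy here.

The compounds shown compare only these two groups at this place, so it remains open whether an amine, a methoxy group or a carboxylic acid there would give a number closer to that of compound 4 or compound 1. On these data alone, it also remains open whether the same exchange would give a step of similar size on a different core.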